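Benzofuranyl-to-iodo swap in a nucleoside series

The source may report more compounds than this note shows. Statements on the series, on what has been measured and on what is new or still open speak of the compounds shown alone.

Measured so far:
compound 1 `CN(C)c1ncnc2c1c(-c1cc3ccccc3o1)cn2[C@@H]1O[C@H](CO)[C@@H](O)[C@H]1O` — in a functional assay on HeLa S3 cells (Homo sapiens) for antiproliferative activity, read by XTT assay, with a stated time of 72 h (on this read-out higher numbers stand for weaker inhibition and lower numbers for stronger inhibition), compound 1 gives > 20000 nM, a limit of the assay.
compound 2 `Cc1ncnc2c1c(-c1cc3ccccc3o1)cn2[C@@H]1O[C@H](CO)[C@@H](O)[C@H]1O` — in this assay compound 2 gives > 20000 nM, a limit of the assay.
compound 3 `CNc1ncnc2c1c(-c1cc3ccccc3o1)cn2[C@@H]1O[C@H](CO)[C@@H](O)[C@H]1O` — in this assay compound 3 gives > 20000 nM, a limit of the assay.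

Compound 2 stands at the limit of this assay, and the two other values shown sit at the same limit (the limit of > 20000 nM in this assay, at which 3 of the 3 values shown sit). The three measured steps, a step that the two limits leave unreadable from compound 1 to compound 2, a step that the two limits leave unreadable from compound 1 to compound 3 and a step that the two limits leave unreadable from compound 2 to compound 3, are all unreadable, so no size can be taken from any of them.

Compound 4 `Cc1ncnc2c1c(I)cn2[C@@H]1O[C@H](CO)[C@@H](O)[C@H]1O` differs from compound 2 in one place: iodo in place of 1-benzofuran-2-yl on an aromatic carbon. Among the compounds with values here, none of the measured steps changes this position; all three alter only the group on the six-membered ring of the core of compound 2, and all leave the value at the limit. Within the data shown here, there is therefore no measured step that bears on the change to compound 4, and no direction can be read.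

With every value shown sitting at the limit, compound 4 is expected to remain near it as well, with the step from compound 2 estimated as a step that the limit leaves unreadable from compound 2 to compound 4. The estimate for compound 4 in this assay is 30000 nM, within a range of 5000 nM to 200000 nM, and a limit rather than a number is the most likely outcome.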

Compound 4, half-maximal inhibitory concentration: 4080 nM
Compound 4: middle estimate off by 7.4-fold (0.87 log units), on the high side; the measured number lies below the stated range.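

In this assay, iodo in place of 1-benzofuran-2-yl on this carbon of the five-membered aromatic ring gives an at least 4.9-fold lower number from compound 2 to compound 4 (0.69 log units; beyond the scatter), the only readable step among the compounds shown, since the steps among compound 1, compound 2 and compound 3 cannot be read. Compound 2 gives > 20000 nM, which is a limit of the assay and not a number. This carbon is therefore the one place shown where a change brings a compound off the limit, and compound 4 is the only compound with a measured number: the limit of > 20000 nM in this assay, at which 3 of the 4 values shown sit.

From the compounds shown here alone, whether the number of compound 4 depends on iodo itself or only on the loss of 1-benzofuran-2-yl remains open, and bromo, chloro, ethynyl or phenyl on the same carbon would bear on that question. Also open, going by these compounds, is whether the gain carries over when iodo is paired with methylamino or dimethylamino in place of methyl on the other aromatic carbon, as in compound 3 and compound 1.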